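Series notes: 3-acetylphenyl in place of 3,5-dimethoxyphenyl

A few compounds are considered here, and "the series" means these few. Any claim that something is new, unique, unknown or untested is made for them only; others in the source may bear on it.

In a functional assay on MDA-MB-231 cells (Homo sapiens) for antiproliferative activity, read by MTT assay, with a stated time of 72 h (on this read-out higher numbers stand for weaker inhibition and lower numbers for stronger inhibition), compound 3 `COc1cc(OC)cc(-c2cccc(NC(=O)CCc3cccc4c3B(O)OC4)c2)c1` gives 40 nM as the lowest of three numbers, ahead of compound 2 `COc1ccc(-c2cccc(NC(=O)CCc3cccc4c3B(O)OC4)c2)cc1` at 88 nM and compound 1 `CC(C)c1cccc(NC(=O)CCc2cccc3c2B(O)OC3)c1` at 1600 nM on the same read-out.

The next structure is compound 4 `CC(=O)c1cccc(-c2cccc(NC(=O)CCc3cccc4c3B(O)OC4)c2)c1` with the difference 3-acetylphenyl in place of 3,5-dimethoxyphenyl on an aromatic carbon in view. It carries 3-acetylphenyl in place of 3,5-dimethoxyphenyl on an aromatic carbon, meta to a large group.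

The steps of an 18-fold lower number from compound 1 to compound 2 (1.26 log units; beyond the scatter) and a 40-fold lower number from compound 1 to compound 3 (1.60 log units; beyond the scatter) are both large, and each replaces isopropyl with a substituted phenyl group. Compound 4 keeps a substituted phenyl group at that place, so a fall back towards the number of compound 1 is not expected. The closest guide is the modest step of a 2.2-fold lower number from compound 2 to compound 3 (0.34 log units; beyond the scatter) between two such groups, which suggests that changes among them move the number only a little. Within the data shown here, no measured compound carries an acetyl group, so this guide is indirect.

A small move towards a higher number is expected in this assay with a 1.9-fold higher number from compound 3 to compound 4 (0.27 log units; within the scatter) as the estimated step.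

Compound 4 is expected at 75 nM with an estimated range from 30 nM to 200 nM as the working figure.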

Compound 4, half-maximal inhibitory concentration: 52 nM
For compound 4 the middle estimate is 1.4-fold (0.16 log units) above the measured one; the measured number falls inside the stated range.
By their numbers in this assay, from the lowest: compounds 3, 4 and 2 (each within the scatter of the next, the first and the last beyond it); then compound 1.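

Notes on the added phenyl ring: in this assay the large gain over isopropyl does not depend on methoxy groups, since 3-acetylphenyl, which carries none, also gives a large step (a 31-fold lower number from compound 1 to compound 4 (1.49 log units; beyond the scatter)) at this aromatic carbon. Against the methoxy-bearing rings, the steps (a 1.3-fold higher number from compound 3 to compound 4 (0.11 log units; within the scatter)) and (a 1.7-fold lower number from compound 2 to compound 4 (0.23 log units; within the scatter)) both stay within the scatter, so compound 4 cannot be ordered against either compound, although compound 2 and compound 3 are separated by a modest step beyond the scatter. The data therefore show that this position accepts an acetyl group as well as methoxy groups on the added ring, but no supporting measurement bears on why this result arises.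

The compounds shown leave open whether a plain phenyl ring, or a phenyl ring carrying an amine or a carboxylic acid, would hold the number at the level of compound 3 and compound 4. They also leave open whether a nitrogen-containing aromatic ring at this place, or a longer chain joining it to the core, would keep the gain seen over compound 1.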